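Swapping a Halogen for a Methyl on a Phthalimide Aminal

The compounds below may be only part of what the source reports. "The series", "measured", "known", "first", "only" and "open" are said of these compounds alone.

Measured so far:
- compound 1, `O=C1c2ccccc2C(=O)N1CNc1ccc(F)cc1`, 56.7%
- compound 2, `O=C1c2ccccc2C(=O)N1CNc1ccc(Cl)cc1`, 8.52%

Both were tested in an assay on isolated protein for inhibition of ribosomal protein S6 kinase alpha-2 (Homo sapiens), read by fluorescence, with a stated time of 20 min, tested at 10 uM; a higher number here means more inhibition at the concentration tested (going by the name of the read-out), a lower number less inhibition. Compound 2 gives 8.52%, the lowest of the two numbers; its nearest neighbour is compound 1, and the step of a number 48.2 percentage points lower from compound 1 to compound 2 (beyond the scatter) is large and beyond the usual scatter.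

Compound 3, `Cc1ccc(NCN2C(=O)c3ccccc3C2=O)cc1`, has not yet been measured. It differs from compound 2 by methyl in place of chloro on an aromatic carbon. Within the data shown here, only one measured step exists, the one from compound 1 to compound 2, and it involves a different pair of groups, so it bears on this change only loosely: it shows that a single change at this position can move the read-out a great deal. The direction for a methyl cannot be read from the two compounds alone. Compound 3 is therefore expected to land somewhere between its two neighbours, estimated at 25% with a wide range from 2% to 60%, meaning an expected step of a number 16.5 percentage points higher from compound 2 to compound 3 (beyond the scatter).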

Compound 3, a percentage reported as inhibition, at one concentration (the size of the read-out at that concentration, not a potency): 54%
Compound 3: the middle estimate sits 29 percentage points below what was measured; measured number inside the range.
By their numbers in this assay, from the lowest: compound 2; then compounds 3 and 1 (each within the scatter of the next).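

In this assay, methyl in place of chloro gives a number 45.5 percentage points higher from compound 2 to compound 3 (beyond the scatter) and so shows that the low number of the chloro compound does not extend to every small group at this place on the ring. Methyl in place of fluoro gives a number 2.7 percentage points lower from compound 1 to compound 3 (within the scatter) and so leaves these two groups indistinguishable here, with chloro alone standing apart among the three compounds. No measurement available here explains why one single-atom swap at this position matters so much while another does not.

As far as these compounds go, whether bromo, an amine or a carboxylic acid at this place would fall with chloro or with fluoro and methyl remains open. Three compounds also cannot show whether the low chloro number would persist if the shared core were changed.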